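Isopropyl to butyl on the shared core

The source may report more compounds than this note shows. Statements on the series, on what has been measured and on what is new or still open speak of the compounds shown alone.

In an ADME assay on the whole organism with Oryza sativa as the target, tested at 10 uM (a lower number here means a stronger effect, a higher number a weaker effect of the compound at the concentration tested), three compounds have numbers. Compound 1 `CC(C)c1cccc(NC(=O)N[C@@H](C)c2ccccc2)c1` gives 86%. Compound 2 `CC(C)c1ccc(NC(=O)N[C@H](C)c2ccccc2)cc1` gives 49%, and compound 3 `CC(C)c1ccc(NC(=O)N[C@@H](C)c2ccccc2)cc1` gives 86%. Compound 3 thus stands level with compound 1 at the digits shown, the two together at the top of the three numbers. Going by the values given here, its only step to a measured neighbour is a number 37 percentage points higher from compound 2 to compound 3 (beyond the scatter), which rests on (the fact that compounds 2 and 3 differ only in the configuration as drawn).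

Compound 4 `CCCCc1ccc(NC(=O)N[C@@H](C)c2ccccc2)cc1` is the next one to be measured. It differs from compound 3 by butyl in place of isopropyl on an aromatic carbon. Among the compounds with values here, no measured pair changes the alkyl group, so no measured step bears on this change, and the configurational step between compound 2 and compound 3 says nothing about it. The expected step is therefore a number 2 percentage points lower from compound 3 to compound 4 (within the scatter), none beyond the scatter. Compound 4 is estimated at 84%, with a range from 66% to 96%.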

Compound 4, a percentage reported as activity, at one concentration (the size of the read-out at that concentration, not a potency): 60%
The estimate for compound 4 lay 24 percentage points above the measured number, and the stated range ends above it.
By their numbers in this assay, from the lowest: compound 2; then compound 4; then compounds 1 and 3 (each within the scatter of the next).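

In this assay butyl in place of isopropyl gives a number 26 percentage points lower from compound 3 to compound 4 (beyond the scatter) and so a stronger effect at the concentration tested. This aromatic carbon, para to a large group, therefore responds to a change of alkyl group, even though both groups are plain carbon chains with no ring and no net charge. Nothing available bears on the cause of this step.

Open remain how a propyl group, a longer chain or an amine would read at this place. Going by these compounds, it is also open whether butyl would shift the number the same way in the configuration of compound 2.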